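This account rests on a few compounds, and the source may have more. Where it says the series, first, only, none or still open, it means among the compounds named here.

Of the compounds shown here, three sharing one core have been measured in a functional assay on HeLa cells (Homo sapiens) for cytotoxicity, read by cell counting, with a stated time of 4 days; a higher number here means a weaker inhibitor, a lower number a stronger inhibitor. Compound 1 `C=C(Br)C(=O)Nc1ccc(/C=C2\SC(=O)N(Cc3ccc(C)cc3)C2=O)cc1` gives 8900 nM. Compound 2 `C=C(Br)C(=O)Nc1ccc(/C=C2\SC(=O)N(CC)C2=O)cc1` gives 1400 nM. Compound 3 `C=C(Br)C(=O)Nc1ccc(/C=C2\SC(=O)N(Cc3ccc(F)cc3)C2=O)cc1` gives 2000 nM, the second highest of the three numbers: it lies close to compound 2, a 1.4-fold higher number from compound 2 to compound 3 (0.15 log units; within the scatter), and well apart from compound 1, a 4.5-fold lower number from compound 1 to compound 3 (0.65 log units; beyond the scatter).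

Compound 4 `C=C(Br)C(=O)Nc1ccc(/C=C2\SC(=O)N(C)C2=O)cc1` has not been measured yet. It differs from compound 3 by hydrogen in place of 4-fluorophenyl on a saturated chain carbon bound to an amide-type nitrogen in a ring. Within the data shown here, two measured steps bear on this change. The step of a 6.4-fold lower number from compound 1 to compound 2 (0.80 log units; beyond the scatter) removed a larger aromatic group from the same place and clearly lowered the number. The step of a 1.4-fold higher number from compound 2 to compound 3 (0.15 log units; within the scatter) put the 4-fluorophenyl back and stayed within the scatter. Trimming 4-fluorobenzyl down to methyl should therefore behave much like the first of these. Only a small drop in the number, or none beyond the scatter, is expected for the step of a 1.7-fold lower number from compound 3 to compound 4 (0.22 log units; within the scatter). Compound 4 is estimated at 1200 nM, with a range from 500 nM to 3000 nM.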

Compound 4, half-maximal inhibitory concentration: 870 nM
Compound 4: the middle estimate sits 1.4-fold (0.14 log units) above what was measured; the measured number falls inside the stated range.
By their numbers in this assay, from the lowest: compounds 4, 2 and 3 (each within the scatter of the next, the first and the last beyond it); then compound 1.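

In this assay, trimming 4-fluorobenzyl to methyl gives a change beyond the scatter (a 2.3-fold lower number from compound 3 to compound 4 (0.36 log units; beyond the scatter)), whereas the ethyl and 4-fluorobenzyl compounds could not be told apart. Ethyl and methyl also cannot be told apart (a 1.6-fold lower number from compound 2 to compound 4 (0.21 log units; within the scatter)), so the two short chains read alike here, while the full span at this position reaches from the 4-methylbenzyl group to methyl (a 10-fold lower number from compound 1 to compound 4 (1.01 log units; beyond the scatter)). Nothing available explains why these groups differ.

The shown groups at this position are only short chains and benzyl groups carrying methyl or fluoro on the aromatic ring. On these data alone, it remains open how an amine, a carboxylic acid, a longer chain such as butyl or an unsubstituted benzyl would compare.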